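Para-aryl variation on the shared core: compound 3 to compound 4

The source may report more compounds than this note shows. Statements on the series, on what has been measured and on what is new or still open speak of the compounds shown alone.

The shared core of compound 1 `Cc1ccccc1-n1nc(C)c2c1NC(=O)[C@H](C)S[C@@H]2c1ccc(Oc2ccccc2)cc1` carries a phenoxy group that, in compound 2 `Cc1ccccc1-n1nc(C)c2c1NC(=O)[C@H](C)S[C@@H]2c1ccc(-c2ccsc2)cc1` and compound 3 `Cc1ccccc1-n1nc(C)c2c1NC(=O)[C@H](C)S[C@@H]2c1ccc(-c2cc3ccccc3o2)cc1`, is exchanged for thiophen-3-yl and 1-benzofuran-2-yl. In an assay on isolated protein for agonist activity at Bile acid receptor (Homo sapiens), read by AlphaScreen, with a stated time of 30 min (a lower number here means that less compound is needed, a higher number that more compound is needed for the effect), compound 1 gives 1300 nM, compound 2 gives 1400 nM and compound 3 gives 1500 nM. Compound 3 stands at the highest of the three numbers, but its nearest neighbour lies only a 1.1-fold higher number from compound 2 to compound 3 (0.03 log units; within the scatter) and its furthest only a 1.2-fold higher number from compound 1 to compound 3 (0.06 log units; within the scatter), so no order among the three can be read.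

Compound 4 `Cc1ccccc1-n1nc(C)c2c1NC(=O)[C@H](C)S[C@@H]2c1ccc(-c2cccc(C(=O)O)c2)cc1` follows from compound 3 by 3-carboxyphenyl in place of 1-benzofuran-2-yl on an aromatic carbon. Among the measured compounds shown here, the steps that bear on this position, a 1.1-fold higher number from compound 1 to compound 2 (0.03 log units; within the scatter) and a 1.1-fold higher number from compound 2 to compound 3 (0.03 log units; within the scatter), were both within the scatter, so the three exchanges at this aromatic carbon left this assay essentially unchanged. For the measured compounds named here, no measured step covers a carboxyl group, so the direction of any effect of the 3-carboxyphenyl group cannot be drawn from the data. Given that every recorded change at this site stayed within the scatter, compound 4 is expected near compound 3, with the step of a 1.4-fold lower number from compound 3 to compound 4 (0.13 log units; within the scatter) estimated as small, and the value for compound 4 estimated at 1100 nM, within 300 nM to 4000 nM.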

Compound 4, half-maximal effective concentration: "not active" (no number reported)
For compound 4 the study gives words and no number, so the estimate cannot be set against anything.
By their numbers in this assay, from the lowest: compounds 1, 2 and 3 (each within the scatter of the next).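

Compound 4 is reported in this assay as "not active", in words without a number, so no new step can be read from compound 3 to compound 4. The compounds shown leave open how far compound 4 lies from compound 3 and whether other carboxyl-bearing groups at this aromatic carbon give the same report. No available evidence bears on this result.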